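Moving the chlorine on compound 3

This account rests on a few compounds, and the source may have more. Where it says the series, first, only, none or still open, it means among the compounds named here.

In a functional assay on PC-3 cells (Homo sapiens) for cytotoxicity, read by sulforhodamine B assay, with a stated time of 72 h (a lower number here means a stronger inhibitor of growth, a higher number a weaker inhibitor of growth), compound 1 `O=C(Nc1ccccc1C(F)(F)F)C1CCc2ccccc2N1` gives 53300 nM as its concentration for half-maximal growth inhibition. Compound 2 `CCC(=O)N1c2ccccc2CCC1C(=O)Nc1ccccc1C(F)(F)F`, with propanoyl in place of hydrogen on a nitrogen, has > 80000 nM as its reading, which is a limit and not a number. Compound 3 `O=C(Nc1ccccc1C(F)(F)F)C1CCc2ccccc2N1C(=O)c1cccc(Cl)c1`, with (3-chlorophenyl)carbonyl on that nitrogen, gives 729 nM and holds the lowest number here. Two large steps lead there: one is a 73-fold lower number from compound 1 to compound 3 (1.86 log units; beyond the scatter) and the other is an at least 100-fold lower number from compound 2 to compound 3 (2.04 log units; beyond the scatter) in a separate comparison. Compound 4 `O=C(Nc1ccccc1C(F)(F)F)C1CCc2ccccc2N1C(=O)c1ccccc1Cl` has the same atoms joined differently, with 2-chlorophenyl in place of 3-chlorophenyl on a carbonyl carbon. Among the measured compounds shown here, those two steps replace whole groups while no measured step moves a chlorine, so they set no size for this change. Compound 3 at 729 nM already sits lowest, so a moderate move towards a higher number is expected. In this assay the expected change is a 2.1-fold higher number from compound 3 to compound 4 (0.31 log units; beyond the scatter) and it may prove modest. Compound 4 is estimated at 1500 nM with 400 nM to 8000 nM as the expected range.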

Compound 4, concentration for 50% growth inhibition: 5140 nM
Compound 4: middle estimate off by 3.4-fold (0.53 log units), on the low side; measured number inside the range.
By their numbers in this assay, from the lowest: compound 3; then compound 4; then compound 1. At a limit, above all of these: compound 2.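

In this assay, among the compounds shown here, compound 3 and compound 4 have the same atoms, and moving the chlorine alone gives a 7.1-fold higher number from compound 3 to compound 4 (0.85 log units; beyond the scatter), so the place of the chlorine on this ring changes the result, which the earlier steps could not show because each replaced a whole group. The 2-chlorophenyl group keeps much of the gain seen on this nitrogen, with a 10-fold lower number from compound 1 to compound 4 (1.02 log units; beyond the scatter). Replacing ethyl on the carbonyl carbon gives an at least 15-fold lower number from compound 2 to compound 4 (1.19 log units; beyond the scatter), but this size is only a floor, as its starting reading is a limit and not a number: the limit of > 80000 nM in this assay, at which 1 of the 4 values shown sits.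

The compounds shown do not explain why the place of the chlorine matters. They also leave open what a methoxy group or a carboxylic acid would do in place of the chlorine on this ring.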